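Compound 1 to compound 4: a swap on the amide nitrogen

The source may report more compounds than this note shows. Statements on the series, on what has been measured and on what is new or still open speak of the compounds shown alone.

Measured in an ADME assay on MT4 cells (Homo sapiens) for cytotoxicity, read by MTT assay, with a stated time of 5 days; on this read-out higher numbers stand for lower toxicity in this test and lower numbers for higher toxicity in this test:
compound 1 `Cc1ccc(NC(=O)CSc2nc3ccccc3n2S(=O)(=O)c2cc(C)cc(C)c2)cc1`: 2970 nM
compound 2 `Cc1cc(C)cc(S(=O)(=O)n2c(OCC(=O)Nc3ccccc3Br)nc3ccccc32)c1`: > 243000 nM (a limit of the assay, not a number)
compound 3 `COC(=O)c1ccc(NC(=O)COc2nc3ccccc3n2S(=O)(=O)c2cc(C)cc(C)c2)c(Cl)c1`: 119000 nM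

Compound 1 holds the lower of the two actual numbers, well beyond the scatter from compound 3. Compound 4 `Cc1cc(C)cc(S(=O)(=O)n2c(SCC(=O)Nc3ccccc3Br)nc3ccccc32)c1` departs from compound 1 at one place: 2-bromophenyl in place of 4-methylphenyl on an amide-type nitrogen. That is 2-bromophenyl in place of 4-methylphenyl on an amide-type nitrogen. Among the compounds with values here, only one measured step changes this nitrogen, an at least 2.0-fold lower number from compound 2 to compound 3 (0.31 log units; beyond the scatter), and it starts from the limit of > 243000 nM in this assay, at which 1 of the 3 values shown sits. That step shows that a swap here can move the number, but compounds 2 and 3 also differ from compound 1 elsewhere, so it gives only a loose guide. The expected change is a 2.7-fold higher number from compound 1 to compound 4 (0.43 log units; beyond the scatter), towards a higher number in this assay. For compound 4 the estimate is 8000 nM, with an expected range of 2000 nM to 40000 nM.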

Compound 4, half-maximal cytotoxic concentration: >= 235000 nM
Compound 4 gave a limit, no number; the forecaster's own chance of this, stated with the estimate: 8%; middle value at least 29-fold (1.46 log units) from the limit.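

In this assay, 2-bromophenyl in place of 4-methylphenyl on the amide-type nitrogen, with the rest of compound 1 unchanged, gives an at least 79-fold higher number from compound 1 to compound 4 (1.89 log units; beyond the scatter). The value of compound 4 is a limit, not a number: the limit of >= 235000 nM in this assay, at which 1 of the 4 values shown sits. This single swap is thus enough to carry the series from a measured number to a limit, a larger shift at this nitrogen than the earlier step showed.

Open, on these data alone, is whether the shift follows the entering bromine or the leaving methyl. A plain phenyl on this nitrogen would separate the two.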